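The source may hold more compounds than are shown below. What is called first, only, known or untested is meant among the compounds shown, and "the series" means these compounds.

Within the data shown here, compound 1 `O=C(CSc1nc2c(c(=O)n1-c1ccccc1)SCC2)Nc1ccc(-c2cccs2)cn1` gives 0.3 nM in an assay on L cells for inhibition of Protein-serine O-palmitoleoyltransferase porcupine (Mus musculus), read by reporter gene assay, with a stated time of 24 h (a higher number here means that more compound is needed for the effect, a lower number that less compound is needed), and stands lowest of the three numbers measured so far. Compound 2 `COc1ccc(-n2c(SCC(=O)Nc3nc4ccc(OC)cc4s3)nc3c(c2=O)SCC3)cc1` gives 120 nM in this assay, and compound 3 `COc1ccc2nc(NC(=O)CSc3nc4c(c(=O)n3-c3ccccc3)SCC4)ccc2c1` gives 580 nM in this assay; both sit far above compound 1, beyond the scatter, so compound 1 is the most potent of the three. Among the measured compounds shown here, neither compound 2 nor compound 3 differs from compound 1 in a single place, so no step between measured compounds is available to lean on. The next compound, compound 4 `O=C(CSc1nc2c(c(=O)n1-c1ccccc1)SCC2)Nc1ccc(-c2cccnc2)cn1`, keeps the shared core of compound 1 and differs only by pyridin-3-yl in place of thiophen-2-yl on an aromatic carbon. The measured compounds say nothing about this particular exchange, and the starting point of compound 1 leaves more room for loss than for gain. A modest loss is expected, with an estimated step of a 5.0-fold higher number from compound 1 to compound 4 (0.70 log units; beyond the scatter) in this assay toward a higher number, though a step within the scatter would not surprise. For compound 4 in this assay the expected value is 1.5 nM, with a range from 0.3 nM to 8 nM.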

Compound 4, half-maximal effective concentration: 1 nM
Compound 4: middle estimate off by 1.5-fold (0.18 log units), on the high side, and the stated range covers the measured number.
By their numbers in this assay, from the lowest: compound 1; then compound 4; then compound 2; then compound 3.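

Among these compounds, on the six-membered aromatic ring with 1 nitrogen, para to a large group, the first direct exchange at this position in this assay puts pyridin-3-yl in place of thiophen-2-yl and gives a 3.3-fold higher number from compound 1 to compound 4 (0.52 log units; beyond the scatter) as a modest step beyond the scatter. The thiophen-2-yl group is therefore not essential for a low number, since compound 4 with a six-membered aromatic ring still gives 1 nM in this assay. No available evidence accounts for the size of this step.

From the compounds shown here alone, whether this position needs an aromatic ring at all remains open, and a plain phenyl ring, a morpholine or a carboxylic acid here would address that. Pyridin-2-yl and pyridin-4-yl would show whether the place of the ring nitrogen in the entering group matters.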